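This account rests on a few compounds, and the source may have more. Where it says the series, first, only, none or still open, it means among the compounds named here.

Working notes on the series. Compound 1 `COc1cccc([C@H](c2cc3cc(Br)ccc3nc2OC)[C@@](O)(CCN(C)C)c2cc(SC)nc(SC)c2)c1F` gives 17 uL/min in an ADME assay on microsomes from liver (Mus musculus) for metabolic stability; a lower number here means slower removal, a higher number faster removal of the compound. Compound 2 `COc1cccc([C@H](c2cc3cc(C#N)ccc3nc2OC)[C@@](O)(CCN(C)C)c2cc(SC)nc(SC)c2)c1F` gives 20 uL/min in this assay; the step of a 1.2-fold higher number from compound 1 to compound 2 (0.07 log units; within the scatter) leaves compound 2 and compound 1 within the scatter of each other, and compound 2 has no other measured neighbour. Compound 3 `CCSc1cc([C@](O)(CCN(C)C)[C@@H](c2cc3cc(C#N)ccc3nc2OC)c2cccc(OC)c2F)cc(SCC)n1` differs from compound 2 as follows: a group of 12 heavy atoms (9 carbon, 1 nitrogen, 2 sulfur; one six-membered aromatic ring with 1 hetero atom) in place of a group of 10 heavy atoms (7 carbon, 1 nitrogen, 2 sulfur; one six-membered aromatic ring with 1 hetero atom), on a saturated chain carbon bound to an oxygen on a saturated carbon and two saturated chain carbons. Going by the values given here, no measured step touches this part of the shared core, so nothing in the data sets a direction for this assay beyond the scatter. The expected step of a 1.2-fold higher number from compound 2 to compound 3 (0.08 log units; within the scatter) is therefore small. Compound 3 is estimated at 24 uL/min, in the range 12 uL/min to 48 uL/min.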

Compound 3, intrinsic clearance in a liver preparation (reported as CLH), per the amount of preparation that the assay uses: 27 uL/min
Compound 3: the middle estimate sits 1.1-fold (0.05 log units) below what was measured, within the range that was stated.
By their numbers in this assay, from the lowest: compounds 1, 2 and 3 (each within the scatter of the next).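

In this assay, going by these compounds alone, the group of 12 heavy atoms in place of the group of 10 heavy atoms gives a 1.4-fold higher number from compound 2 to compound 3 (0.13 log units; within the scatter) and is the first measured change at this part of the shared core. Both groups hold the same six-membered aromatic ring with 1 hetero atom, and this gain of heavy atoms leaves the number within the scatter. Nothing available bears on a cause for this result. Still open, as far as these compounds go, is whether a longer chain, an amine or a carboxylic acid on that ring would give a step beyond the scatter. Also open, from the compounds shown here alone, is whether the same change would give a similar step with bromo in place of cyano.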